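This account rests on a few compounds, and the source may have more. Where it says the series, first, only, none or still open, it means among the compounds named here.

Two compounds with a shared core have numbers in a functional assay on HT-29 cells (Homo sapiens) for cytotoxicity, read by MTT assay; on this read-out higher numbers stand for weaker inhibition and lower numbers for stronger inhibition. Compound 1 `C=C1C(=O)[C@]23C[C@@]1(F)CC[C@H]2[C@@]12C=CC(=O)[C@](C)(C(=O)O1)[C@H]2[C@@H]3C(=O)OC` gives 72700 nM, and compound 2 `C=C1C(=O)[C@]23C[C@@]1(I)CC[C@H]2[C@@]12C=CC(=O)[C@](C)(C(=O)O1)[C@H]2[C@@H]3C(=O)OC` gives 51900 nM. These two values lie within the scatter of each other, so compound 2 cannot be told apart from compound 1.

Compound 3 `C=C1C(=O)[C@]23C[C@@]1(OCC)CC[C@H]2[C@@]12C=CC(=O)[C@](C)(C(=O)O1)[C@H]2[C@@H]3C(=O)OC` has ethoxy in place of iodo on a saturated ring carbon. For the measured compounds named here, the only measured step at this carbon is a 1.4-fold lower number from compound 1 to compound 2 (0.15 log units; within the scatter), which stays within the scatter. It swaps one halogen for another, and neither measured compound carries an ethoxy, so it is only a weak guide. No step beyond the scatter is therefore expected in this assay, in either direction. The estimated value for compound 3 is 50000 nM, with an expected range from 20000 nM to 100000 nM. This estimate means an expected 1.0-fold lower number from compound 2 to compound 3 (0.02 log units; within the scatter).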

Compound 3, half-maximal inhibitory concentration: 34100 nM
The estimate for compound 3 lay 1.5-fold (0.17 log units) above the measured number; measured number inside the range.
By their numbers in this assay, from the lowest: compounds 3, 2 and 1 (each within the scatter of the next, the first and the last beyond it).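

In this assay, for the compounds shown here, the ethoxy group is the first substituent on this saturated ring carbon that is not a halogen, and replacing iodo with it gives a 1.5-fold lower number from compound 2 to compound 3 (0.18 log units; within the scatter), so that swap cannot be told from noise. Going by these compounds alone, replacing fluoro with ethoxy gives a 2.1-fold lower number from compound 1 to compound 3 (0.33 log units; beyond the scatter), the first step at this position to pass the scatter, though only modestly, and with compound 2 within the scatter of both compound 1 and compound 3, the three form a narrow spread and not a clear ranking. No measurement is available that would explain this small step.

From the compounds shown here alone, whether an amine, a carboxylic acid or a longer ether chain on this carbon would give a larger step remains open. So does whether any group here could move the number well outside this narrow spread.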